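Carboxy in Place of Aminopropyl on the Dipeptide Side Chain

The compounds below may be only part of what the source reports. "The series", "measured", "known", "first", "only" and "open" are said of these compounds alone.

Compound 2 `Cc1cn(C2OC(CO[Si](C)(C)C(C)(C)C)C3(OS(=O)(=O)C=C3N)C2O[Si](C)(C)C(C)(C)C)c(=O)n(CCCNC(=O)[C@@H]2CCCN2C(=O)[C@@H](N)CCCCN)c1=O` carries a 3-aminopropyl group on a saturated chain carbon, two bonds along the chain from an amine nitrogen and a carbonyl carbon. Going by the values given here, in a functional assay on CCRF-CEM cells (Homo sapiens) for antiproliferative activity (on this read-out higher numbers stand for lower toxicity in this test and lower numbers for higher toxicity in this test), compound 2 gives 47000 nM, the highest number among the three compounds measured so far. Compound 1 `Cc1cn(C2OC(CO[Si](C)(C)C(C)(C)C)C3(OS(=O)(=O)C=C3N)C2O[Si](C)(C)C(C)(C)C)c(=O)n(CCCNC(=O)[C@@H]2CCCN2C(=O)[C@H](C)N)c1=O`, with hydrogen at that place, gives 19000 nM in this assay, and compound 3 `Cc1cn(C2OC(CO[Si](C)(C)C(C)(C)C)C3(OS(=O)(=O)C=C3N)C2O[Si](C)(C)C(C)(C)C)c(=O)n(CCCNC(=O)[C@@H]2CCCN2C(=O)[C@@H](N)CC(N)=O)c1=O`, with carbamoyl there, gives 25000 nM. Replacing hydrogen by 3-aminopropyl gave a 2.5-fold higher number from compound 1 to compound 2 (0.39 log units; beyond the scatter), while replacing hydrogen by carbamoyl gave a 1.3-fold higher number from compound 1 to compound 3 (0.12 log units; within the scatter), and exchanging 3-aminopropyl for carbamoyl gave a 1.9-fold lower number from compound 2 to compound 3 (0.27 log units; within the scatter).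

Compound 4 `Cc1cn(C2OC(CO[Si](C)(C)C(C)(C)C)C3(OS(=O)(=O)C=C3N)C2O[Si](C)(C)C(C)(C)C)c(=O)n(CCCNC(=O)[C@@H]2CCCN2C(=O)[C@@H](N)CC(=O)O)c1=O` differs from compound 2 in one place: carboxy in place of 3-aminopropyl on a saturated chain carbon, two bonds along the chain from an amine nitrogen and a carbonyl carbon. Among the compounds with values here, the step that bears most directly on this change is the one from compound 2 to compound 3, where another group replaced 3-aminopropyl at the same place and the number moved only within the scatter; the step from compound 1 to compound 2 shows that this place can, however, shift the read-out beyond the scatter. Taken together, compound 4 is expected to give a lower number than compound 2, with an expected step of a 1.6-fold lower number from compound 2 to compound 4 (0.19 log units; within the scatter) in this assay. The estimate for compound 4 is therefore 30000 nM, expected to fall between 12000 nM and 75000 nM.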

Compound 4, half-maximal cytotoxic concentration: >= 125000 nM
Compound 4: no number, only a limit; the forecaster's own chance of this, stated with the estimate: 10%; middle value at least 4.1-fold (0.61 log units) away from the limit.
By their numbers in this assay, from the lowest: compounds 1, 3 and 2 (each within the scatter of the next, the first and the last beyond it). At a limit, above all of these: compound 4.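

In this assay compound 4 gives no number, only a limit of the assay: the limit of >= 125000 nM in this assay, at which 1 of the 4 values shown sits.

Before this result, the largest change seen at this place on the saturated chain carbon was modest (a 2.5-fold higher number from compound 1 to compound 2 (0.39 log units; beyond the scatter)), whereas carboxy now moves the read-out further, both against the 3-aminopropyl group (an at least 2.6-fold higher number from compound 2 to compound 4 (0.42 log units; beyond the scatter)) and against hydrogen (an at least 6.5-fold higher number from compound 1 to compound 4 (0.81 log units; beyond the scatter)). The sharpest comparison is the smallest exchange: hydroxy in place of amino on a carbonyl carbon, which turns the carbamoyl group of compound 3 into the carboxy group of compound 4, gives a clear step beyond the scatter (an at least 5.0-fold higher number from compound 3 to compound 4 (0.69 log units; beyond the scatter)), so among the compounds shown the outcome at this place depends on that single exchange rather than on the mere presence of a larger group.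

The compounds shown leave open whether a longer chain ending in a carboxylic acid, or the methyl ester of the acid in compound 4, would also reach the limit. They also leave open whether a shorter chain ending in an amine would stay with compound 2 or move towards compound 1, and they give no reason for the shift seen with carboxy.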